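Swapping a dimethoxyphenyl for a bromophenyl on a shared core

The source may report more compounds than this note shows. Statements on the series, on what has been measured and on what is new or still open speak of the compounds shown alone.

Of the compounds shown here, three have been tested in a functional assay on MCF7 cells (Homo sapiens) for inhibition, read by MTT assay, with a stated time of 48 h; on this read-out higher numbers stand for weaker inhibition and lower numbers for stronger inhibition. Compound 1 `COc1ccc(C(c2c[nH]c3ccc(Br)cc23)c2c[nH]c3ccc(Br)cc23)cc1` gives 2300 nM, and compound 3 `Clc1ccc(C(c2c[nH]c3ccc(Br)cc23)c2c[nH]c3ccc(Br)cc23)cc1` gives 3500 nM. Compound 2 `COc1cccc(C(c2c[nH]c3ccc(Br)cc23)c2c[nH]c3ccc(Br)cc23)c1OC` stands highest of the three with 89000 nM, the weakest inhibition on the numbers shown; its nearest neighbour is compound 3 and its furthest is compound 1.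

Compound 4 `Brc1ccc(C(c2c[nH]c3ccc(Br)cc23)c2c[nH]c3ccc(Br)cc23)cc1` has not been measured. It differs from compound 2 in one place: 4-bromophenyl in place of 2,3-dimethoxyphenyl on a saturated chain carbon bound to two aromatic carbons. Going by the values given here, two measured steps bear on this. The step of a 25-fold lower number from compound 2 to compound 3 (1.41 log units; beyond the scatter) replaces the same group by a 4-chlorophenyl and gives a large drop in the number. The step of a 39-fold higher number from compound 1 to compound 2 (1.59 log units; beyond the scatter) shows the reverse move, from a 4-methoxyphenyl to the 2,3-dimethoxyphenyl, and raises the number strongly. Between chloro and methoxy the step of a 1.5-fold higher number from compound 1 to compound 3 (0.18 log units; within the scatter) lies within the scatter, so bromo in place of chloro is unlikely to matter much either. Compound 4 is therefore expected to show a large downward step, a 25-fold lower number from compound 2 to compound 4 (1.41 log units; beyond the scatter). For compound 4 the estimate is 3500 nM, with a range from 1200 nM to 10000 nM.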

Compound 4, half-maximal inhibitory concentration: 3200 nM
Compound 4: middle estimate off by 1.1-fold (0.04 log units), on the high side; low and high end bracket the measured number.
By their numbers in this assay, from the lowest: compounds 1, 4 and 3 (each within the scatter of the next); then compound 2.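

In this assay, bromo on the ring gives a number that cannot be told apart from those of chloro or methoxy at the same place, with a 1.1-fold lower number from compound 3 to compound 4 (0.04 log units; within the scatter) and a 1.4-fold higher number from compound 1 to compound 4 (0.14 log units; within the scatter). The large step, a 28-fold lower number from compound 2 to compound 4 (1.44 log units; beyond the scatter), now matches the one seen with the 4-chlorophenyl group, so among these four compounds only compound 2, with its 2,3-dimethoxyphenyl group, stands apart from the other three. Nothing measured here explains why that group gives so much higher a number.

As far as these compounds go, it remains open whether the large gap comes from having a second methoxy group or from where the methoxy groups sit on the ring. From the compounds shown here alone, it is also open whether a plain phenyl, or a phenyl carrying an amine or a carboxylic acid, would join the close group of three or fall nearer compound 2.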